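The source may report more compounds than this note shows. Statements on the series, on what has been measured and on what is new or still open speak of the compounds shown alone.

Two compounds of the series have numbers in an ADME assay on WI-38 cells (Homo sapiens) for cytotoxicity, read by MTT assay, with a stated time of 48 h; on this read-out higher numbers stand for weaker inhibition and lower numbers for stronger inhibition. Compound 1 `COc1ccc(/C=C2\N=C(c3ccc(C)cc3)N(C(=O)c3nc4c(c(C)nn4-c4ccccc4)c(=O)[nH]3)NC2=O)cc1` gives 36.8 nM there. Compound 2 `Cc1nn(-c2ccccc2)c2nc(C(=O)N3NC(=O)/C(=C/c4ccccc4)N=C3c3ccc(Cl)cc3)[nH]c(=O)c12` gives 55 nM in this assay, the higher of the two numbers, though the gap to compound 1 falls within the scatter, so the two stand together rather than in an order. Compound 3 `Cc1ccc(C2=N/C(=C\c3ccccc3)C(=O)NN2C(=O)c2nc3c(c(C)nn3-c3ccccc3)c(=O)[nH]2)cc1` is not yet measured. It differs from compound 2 in one place: methyl in place of chloro on an aromatic carbon. No step between measured compounds isolates this change, so nothing shown sets its size; with compound 1 and compound 2 lying within the scatter of each other, no step beyond the scatter is expected in either direction in this assay. The expected step from compound 2 to compound 3 is a 1.1-fold lower number from compound 2 to compound 3 (0.04 log units; within the scatter), with a wide range given that no direct step is shown. Compound 3 is estimated at 50 nM, with a range from 22 nM to 115 nM.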

Compound 3, half-maximal inhibitory concentration: 24.5 nM
Compound 3: the middle estimate sits 2.0-fold (0.31 log units) above what was measured, and the stated range covers the measured number.
By their numbers in this assay, from the lowest: compounds 3, 1 and 2 (each within the scatter of the next, the first and the last beyond it).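

In this assay, going by these compounds alone, 4-chlorophenyl to 4-methylphenyl gives a 2.2-fold lower number from compound 2 to compound 3 (0.35 log units; beyond the scatter), the first step that lies beyond the scatter, and so the first sign that the group at this position can register in the read-out. Hydrogen in place of methoxy on an aromatic carbon gives a 1.5-fold lower number from compound 1 to compound 3 (0.18 log units; within the scatter), so that second change shows no step that can be told apart from the scatter. Nothing at hand bears on why methyl and chloro differ at this position.

Open, from the compounds shown here alone, is how this position responds to other groups, such as an amine, a carboxylic acid or a longer chain. Open too, going by these compounds, is whether the chloro to methyl step holds with methoxy on the other aromatic ring, as in compound 1.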